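A few compounds are considered here, and "the series" means these few. Any claim that something is new, unique, unknown or untested is made for them only; others in the source may bear on it.

Measured so far in an ADME assay on H1-HeLa cells (Homo sapiens) for cytotoxicity, read by MTT assay, with a stated time of 3 days; a higher number here means that more compound is tolerated, a lower number that less compound is tolerated
- compound 1 `CNC(=O)c1cc(Oc2ccc3c(C)c(C(=O)OCc4ccccc4)sc3c2)ccn1` gives 18800 nM
- compound 2 `CCOC(=O)c1sc2cc(Oc3ccnc(C(=O)NC)c3)ccc2c1Cl` gives 46900 nM
- compound 3 `CCOC(=O)c1ccc2ccc(Oc3ccnc(C(=O)NC)c3)cc2c1` gives 20800 nM

In this assay compound 3 at 20800 nM lies within the scatter of compound 1 at 18800 nM. Compound 2 at 46900 nM has a higher number than compound 3, and that gap lies beyond the scatter.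

The next compound to be measured is compound 4 `CCC(C)OC(=O)c1ccc2ccc(Oc3ccnc(C(=O)NC)c3)cc2c1`. It differs from compound 3 in one place: ethyl in place of hydrogen on a saturated chain carbon bound to an oxygen next to a carbonyl group and a saturated chain carbon. The same difference reads as ethoxycarbonyl to sec-butoxycarbonyl.

For the measured compounds named here, the measured compounds differ from each other in more than one place, so no measured step shows the size of this change directly. Going by the values given here, the only guide is the narrow spread of the three values, and with so few compounds this is weak support. No step beyond the scatter is therefore expected in this assay, with only a slight lean towards a lower number. The expected size is a 1.2-fold lower number from compound 3 to compound 4 (0.06 log units; within the scatter), an estimate that stays within the scatter. Compound 4 is estimated at 18000 nM, with an expected range from 8000 nM to 40000 nM.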

Compound 4, half-maximal cytotoxic concentration: 16000 nM
Estimate against measurement, compound 4: 1.1-fold (0.05 log units) above, within the range that was stated.
By their numbers in this assay, from the lowest: compounds 4, 1 and 3 (each within the scatter of the next); then compound 2.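

In this assay, for the compounds shown here, the ester chain gives the first change that can be read on its own: going from ethoxycarbonyl to sec-butoxycarbonyl gives a 1.3-fold lower number from compound 3 to compound 4 (0.11 log units; within the scatter) and so leaves the two compounds within the scatter of each other. Compound 1, compound 2 and compound 3 differ from each other in more than one place and could not show this; the pair now shows that ethyl in place of hydrogen on a saturated chain carbon bound to an oxygen next to a carbonyl group and a saturated chain carbon need not move the number in this assay beyond the scatter. Nothing measured here bears on the reason for this result.

Still open, from the compounds shown here alone, is what a free carboxylic acid in place of the ester, a longer chain such as n-hexyl, or a chain carrying an amine would give in this assay on the core of compound 3. Also open is whether the change from ethoxycarbonyl to sec-butoxycarbonyl reads the same on the core of compound 2, as this single step on one core is all that the compounds shown offer.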